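The compounds below may be only part of what the source reports. "The series", "measured", "known", "first", "only" and "open" are said of these compounds alone.

Compound 1 `Cc1nc(N)c2c(-c3ccccc3)cn([C@@H]3O[C@H](CO)[C@@H](O)[C@H]3O)c2n1`. In an ADME assay on BJ cells (Homo sapiens), read by MTT assay, with a stated time of 72 h (a lower number here means a stronger inhibitor, a higher number a weaker inhibitor), compound 1 gives > 100000 nM, which is a limit of the assay rather than a number.
Compound 2 `Nc1nc(N)c2c(-c3ccccc3)cn([C@@H]3O[C@H](CO)[C@@H](O)[C@H]3O)c2n1`. In this assay compound 2 gives > 100000 nM, again a limit of the assay.
Compound 3 `Cc1ncnc2c1c(-c1cccs1)cn2[C@@H]1O[C@H](CO)[C@@H](O)[C@H]1O`. In this assay compound 3 gives > 100000 nM, once more a limit of the assay.

Compound 1 therefore stands only at a limit in this assay, and so do the two compounds measured beside it. Going by the values given here, the one change that can be placed between measured compounds, a step that the two limits leave unreadable from compound 1 to compound 2, cannot be read, since both ends are limits. Among the compounds with values here, the evidence to hand is summed up by the limit of > 100000 nM in this assay, at which 3 of the 3 values shown sit: every value shown sits at the same limit, and no step of any size can be drawn from them.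

Compound 4 `Cc1nc(N)c2c(-c3ccsc3)cn([C@@H]3O[C@H](CO)[C@@H](O)[C@H]3O)c2n1` is not yet measured. It differs from compound 1 by thiophen-3-yl in place of phenyl on an aromatic carbon. Within the data shown here, compound 3 carries a thiophene on a different core and also sits at the limit, but it is separated from compound 1 by more than one change, so its value gives no measured step toward compound 4. With no readable step anywhere, the expected step that the limit leaves unreadable from compound 1 to compound 4 is none beyond the scatter. Compound 4 is expected to give about 150000 nM in this assay, within 50000 nM to 500000 nM, most likely reported as a limit again.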

Compound 4, half-maximal inhibitory concentration: > 100000 nM
Compound 4 was reported as a limit; the forecaster's own chance of this, stated with the estimate: 85%; the middle value lies beyond the limit too.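

Going by these compounds alone, compound 1 and compound 4 both sit at a limit of this assay, so thiophen-3-yl in place of phenyl gives no step that can be read. All the results so far come to one thing: the limit of > 100000 nM in this assay, at which 4 of the 4 values shown sit.

The compounds shown leave open how far their true values lie beyond that limit, and which change, if any, would bring a readable value in this assay.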